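A fluoro-to-methyl swap on a weakly active series

The source may report more compounds than this note shows. Statements on the series, on what has been measured and on what is new or still open speak of the compounds shown alone.

Of the compounds shown here, three sharing one core have been measured in a functional assay on HepG2 cells (Homo sapiens) for inhibition, read by MTT assay, with a stated time of 72 h; a lower number here means a stronger inhibitor, a higher number a weaker inhibitor. Compound 1 `Nc1ccn(C[C@H](O)[C@H]2OC(=O)C(OCc3ccccc3)=C2OCc2ccccc2)c(=O)n1` gives 44300 nM in this assay. Compound 2 `NC1(CCn2cc(F)c(=O)[nH]c2=O)OC(=O)C(OCc2ccccc2)=C1OCc1ccccc1` gives 42800 nM. Compound 3 `O=C1O/C(=C\Cn2c(=O)[nH]c(=O)[nH]c2=O)C(OCc2ccccc2)=C1OCc1ccccc1` gives 44800 nM. Compound 2 holds the lowest of the three numbers, yet its gap to compound 1 and to compound 3 lies within the usual scatter, so the three stand together and none can be called stronger or weaker than the others.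

Compound 4 `Cc1cn(CCC2(N)OC(=O)C(OCc3ccccc3)=C2OCc2ccccc2)c(=O)[nH]c1=O` has not yet been measured. It differs from compound 2 in one place: methyl in place of fluoro on an aromatic carbon. For the measured compounds named here, no measured pair shows this exact change, so the step must be judged from the three values alone, and they sit so close to one another that nothing points toward a move in either direction.

The step in this assay from compound 2 to compound 4 is therefore expected to be a 1.1-fold higher number from compound 2 to compound 4 (0.02 log units; within the scatter), no larger than the scatter. Compound 4 is estimated at 45000 nM in this assay, with a likely range from 20000 nM to 100000 nM.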

Compound 4, half-maximal inhibitory concentration: > 100000 nM
Compound 4: a limit, no number; the forecaster's own chance of this, stated with the estimate: 15%; middle value at least 2.2-fold (0.34 log units) from the limit.
By their numbers in this assay, from the lowest: compounds 2, 1 and 3 (each within the scatter of the next). At a limit, above all of these: compound 4.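

The reading of compound 4 in this assay is a limit of the assay and not a number: the limit of > 100000 nM in this assay, at which 1 of the 4 values shown sits.

Even so, replacing fluoro with methyl on this aromatic carbon, the only difference between the two structures, gives an at least 2.3-fold higher number from compound 2 to compound 4 (0.36 log units; beyond the scatter). The earlier compounds shown here differ from one another in more than one place and stand within the scatter, so they could not show that this position responds to what sits on it.

As far as these compounds go, one pair cannot tell whether the loss of fluoro or the arrival of methyl matters more, and the full size of the step stays unknown. Hydrogen, chloro or an amine on this same carbon would help separate those two readings.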